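Amide variation at the carbonyl of the shared core

The compounds below may be only part of what the source reports. "The series", "measured", "known", "first", "only" and "open" are said of these compounds alone.

Measured so far:
compound 1, `CCCSc1nc(Cl)c2c(n1)N(Cc1ccccc1)C(C(=O)N1CCN(C)CC1)N2`, 2800 nM
compound 2, `CCCSc1nc(Cl)c2c(n1)N(Cc1ccccc1)C(C(=O)NCCCc1ccccc1)N2`, 9430 nM
compound 3, `CCCSc1nc(Cl)c2c(n1)N(Cc1ccccc1)C(C(=O)O)N2`, 10700 nM

In a functional assay on A549 cells (Homo sapiens) for antiproliferative activity, read by MTT assay, with a stated time of 72 h (a lower number here means a stronger inhibitor, a higher number a weaker inhibitor), compound 3 gives the highest of the three numbers. Compound 2 sits nearest to it, the step of a 1.1-fold higher number from compound 2 to compound 3 (0.05 log units; within the scatter), while compound 1 lies furthest away, the step of a 3.8-fold higher number from compound 1 to compound 3 (0.58 log units; beyond the scatter). Among the measured compounds shown here, the only change across these three is the group on the carbonyl carbon: compound 1 carries 4-methylpiperazin-1-yl, compound 2 (3-phenylpropyl)amino, compound 3 hydroxy.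

Compound 4, `CCCSc1nc(Cl)c2c(n1)N(Cc1ccccc1)C(C(=O)NCC(C)C)N2`, continues the same variation: isobutylamino in place of hydroxy on a carbonyl carbon. The step that bears most directly on it is the one from the other neutral amide, a 1.1-fold higher number from compound 2 to compound 3 (0.05 log units; within the scatter), which stayed within the scatter. The larger step of a 3.4-fold higher number from compound 1 to compound 2 (0.53 log units; beyond the scatter) involved the 4-methylpiperazin-1-yl group, which compound 4 does not carry. On that basis compound 4 is expected to show only a small step, a 1.3-fold lower number from compound 3 to compound 4 (0.13 log units; within the scatter), in this assay, probably to a slightly lower number. The estimate for compound 4 is 8000 nM, with a range from 3000 nM to 20000 nM.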

Compound 4, half-maximal inhibitory concentration: 48200 nM
Compound 4: middle estimate off by 6.0-fold (0.78 log units), on the low side; the whole stated range lies below it.
By their numbers in this assay, from the lowest: compound 1; then compounds 2 and 3 (each within the scatter of the next); then compound 4.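

In this assay, replacing hydroxy with isobutylamino on a carbonyl carbon gives a 4.5-fold higher number from compound 3 to compound 4 (0.65 log units; beyond the scatter), so an amide at this position need not match or improve on the carboxylic acid. The amide side chain matters even among amides with a hydrogen on nitrogen: isopropyl in place of phenethyl on a saturated chain carbon bound to an amide-type nitrogen gives a 5.1-fold higher number from compound 2 to compound 4 (0.71 log units; beyond the scatter). The widest gap in the series is now a 17-fold higher number from compound 1 to compound 4 (1.24 log units; beyond the scatter), which makes compound 1 the strongest and compound 4 the weakest of the four.

Open, as far as these compounds go, is whether a dimethylamino group at the end of a straight alkyl chain on the amide nitrogen, or a morpholine in place of the 4-methylpiperazin-1-yl group, would give a number nearer compound 1 or compound 4. No measurement shown here accounts for these steps.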